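A few compounds are considered here, and "the series" means these few. Any claim that something is new, unique, unknown or untested is made for them only; others in the source may bear on it.

Working notes on the series in an ADME assay on MT4 cells (Homo sapiens) for cytotoxicity, read by MTT assay; on this read-out lower numbers stand for higher toxicity in this test and higher numbers for lower toxicity in this test. Compound 1 `Cc1cc(OC2CCCC2)nc(Nc2ccc(C#N)cc2)n1` gives 1050 nM in this assay, the lowest of the numbers measured; the nearest, compound 3 `Cc1cnc(Nc2ccc(C#N)cc2)nc1SC1CCCCC1`, gives 33400 nM. Compound 2 `N#Cc1ccc(Nc2nccc(OC3CCCC3)n2)cc1` reaches only a limit of the assay at >= 339000 nM (the limit of >= 339000 nM in this assay, at which 1 of the 3 values shown sits). Among the measured compounds shown here, the one measured step with a single change, hydrogen in place of methyl, is an at least 320-fold higher number from compound 1 to compound 2 (2.50 log units; beyond the scatter).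

Compound 4 `Cc1cc(NC2CCCCC2)nc(Nc2ccc(C#N)cc2)n1` differs from compound 1 by cyclohexylamino in place of cyclopentyloxy on an aromatic carbon. For the measured compounds named here, no measured step touches this position in one place; compound 3 carries a different ring group there but differs from compound 1 in more than one place, so its value gives no clean guide. Compound 4 is estimated at 3000 nM (range 700 nM to 15000 nM), which means an expected step of a 2.9-fold higher number from compound 1 to compound 4 (0.46 log units; beyond the scatter).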

Compound 4, half-maximal cytotoxic concentration: 340 nM
For compound 4 the middle estimate is 8.8-fold (0.95 log units) above the measured one, outside the stated range (below it).
By their numbers in this assay, from the lowest: compound 4; then compound 1; then compound 3. At a limit, above all of these: compound 2.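

Cyclohexylamino in place of cyclopentyloxy gives a 3.1-fold lower number from compound 1 to compound 4 (0.49 log units; beyond the scatter), the first single-place step at this position in this assay, so the group here moves the read-out toward higher toxicity in this test. The change swaps the linking atom and the ring size together, so the step cannot be assigned to either one alone. Nothing measured here bears on the cause of this step.

Cyclopentylamino or cyclohexyloxy would separate those two parts, while an open-chain amine at this position remains open. The effect of hydrogen in place of methyl is likewise shown only with cyclopentyloxy, not with cyclohexylamino.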